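Swapping the aryl group on a fused core

The source may report more compounds than this note shows. Statements on the series, on what has been measured and on what is new or still open speak of the compounds shown alone.

Compound 1 `Cc1nc2c3ccccc3ccc2c2nc3c(ccc4ccccc43)c(-c3cccnc3)c12`: in a functional assay, with a stated time of 90 s (on this read-out higher numbers stand for weaker inhibition and lower numbers for stronger inhibition), compound 1 gives 156 ug/mL.
Compound 2 `Cc1nc2c3ccccc3ccc2c2nc3c(ccc4ccccc43)c(-c3nccnc3N)c12`: in this assay compound 2 gives 134 ug/mL.
Compound 3 `COc1ccc(-c2c3ccc4ccccc4c3nc3c2c(C)nc2c4ccccc4ccc32)cc1`: in this assay compound 3 gives 176 ug/mL.

Compound 3 shows the highest of the three numbers, though its gaps to the others lie within the scatter: a 1.1-fold higher number from compound 1 to compound 3 (0.05 log units; within the scatter) and a 1.3-fold higher number from compound 2 to compound 3 (0.12 log units; within the scatter). Compound 4 `Cc1nc2c3ccccc3ccc2c2nc3c(ccc4ccccc43)c(-c3cccc4ccccc34)c12` differs from compound 3 by naphthalen-1-yl in place of 4-methoxyphenyl on an aromatic carbon. Within the data shown here, the steps that bear on this all exchange the same aryl group on the shared core: a 1.2-fold lower number from compound 1 to compound 2 (0.07 log units; within the scatter), a 1.1-fold higher number from compound 1 to compound 3 (0.05 log units; within the scatter) and a 1.3-fold higher number from compound 2 to compound 3 (0.12 log units; within the scatter), none of them beyond the scatter. Three quite different groups at this position left the number nearly unchanged, so no step beyond the scatter is expected in this assay; the expected step is a 1.0-fold lower number from compound 3 to compound 4 (0.02 log units; within the scatter). Compound 4 is estimated at 170 ug/mL, with a range from 95 ug/mL to 310 ug/mL.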

Compound 4, half-maximal inhibitory concentration: 179 ug/mL
Compound 4: the middle estimate sits 1.1-fold (0.02 log units) below what was measured; the measured number falls inside the stated range.
By their numbers in this assay, from the lowest: compounds 2, 1, 3 and 4 (each within the scatter of the next).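

In this assay naphthalen-1-yl, with two aromatic rings where the earlier groups have one, still gives no step beyond the scatter: a 1.0-fold higher number from compound 3 to compound 4 (0.01 log units; within the scatter), a 1.3-fold higher number from compound 2 to compound 4 (0.13 log units; within the scatter) and a 1.1-fold higher number from compound 1 to compound 4 (0.06 log units; within the scatter). At this position, then, a second fused ring and the absence of any hydrogen-bond acceptor leave the number indistinguishable from the other three. No measurement shown explains this flat response.

On these data alone, all four groups are aromatic rings, so it remains open whether an amine, a carboxylic acid or a longer chain here would produce a step beyond the scatter.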